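Removing a Ring Methyl on Two Related Cores

A few compounds are considered here, and "the series" means these few. Any claim that something is new, unique, unknown or untested is made for them only; others in the source may bear on it.

Compound 1 `CSc1nc2c(C)nsc2[nH]1` and compound 2 `CSc1nc2cnsc2[nH]1` share one core, while compound 3 `CSc1nc2c(C)nsc2n1[C@@H]1O[C@H](CO)[C@@H](O)[C@H]1O` and compound 4 `CSc1nc2cnsc2n1[C@@H]1O[C@H](CO)[C@@H](O)[C@H]1O` share another; the difference between the two cores is not broken down here. In a functional assay on KB cells (Homo sapiens) for antiproliferative activity (on this read-out higher numbers stand for weaker inhibition and lower numbers for stronger inhibition), compound 1 gives 60000 nM and compound 2 gives 15000 nM. The change between them, (hydrogen in place of methyl on an aromatic carbon), brought a 4.0-fold lower number from compound 1 to compound 2 (0.60 log units; beyond the scatter). For compound 3 the result in this assay is only a limit, > 100000 nM, which is the limit of > 100000 nM in this assay, at which 1 of the 3 values shown sits. Compound 4 is not yet measured and carries the same change, (hydrogen in place of methyl on an aromatic carbon). In this assay a step of similar size is expected, namely an at least 1.6-fold lower number from compound 3 to compound 4 (0.22 log units; that floor lies within the scatter), resting on a 4.0-fold lower number from compound 1 to compound 2 (0.60 log units; beyond the scatter) and tempered by compound 3 starting from a limit. Compound 4 is therefore estimated at 60000 nM, within 15000 nM to 200000 nM.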

Compound 4, half-maximal inhibitory concentration: > 100000 nM
Compound 4 gave a limit, no number; the forecaster's own chance of this, stated with the estimate: 45%; at least 1.6-fold (0.22 log units) between middle value and limit.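

Compound 3 and compound 4 both gave only a limit, so no step between them can be read: the limit of > 100000 nM in this assay, at which 2 of the 4 values shown sit.

The compounds shown leave open whether hydrogen in place of methyl changes the read-out at all on the core of compound 3.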